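The source may hold more compounds than are shown below. What is called first, only, known or untested is meant among the compounds shown, and "the series" means these compounds.

Measured compounds:
Compound 1, `CC(=O)c1nc([C@@H](O)[C@H](O)[C@H](O)CO)cn1C`: in an ADME assay on the whole organism (plasma, strain 129/SvEvBrd x C57BL/6) for pharmacokinetics, with Mus musculus as the target, at a dose of 10 mg/kg by the oral route (a higher number here means more compound in the circulation at the dose given, a lower number less compound in the circulation), compound 1 gives 10000 ng.h/mL.
Compound 2, `CC(O)c1nc([C@@H](O)[C@H](O)[C@H](O)CO)c[nH]1`: in this assay compound 2 gives 10300 ng.h/mL.

Both compounds share a core carrying the same tetrahydroxybutyl chain, and they differ in the group on the ring carbon and in whether the ring nitrogen bears a methyl. Compound 2 gives the higher of the two numbers, but the gap to compound 1 lies within the scatter of repeated measurements, so the two compounds are indistinguishable on this basis.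

Compound 3, `Cn1cnc(-c2nc([C@@H](O)[C@H](O)[C@H](O)CO)c[nH]2)c1`, has not yet been measured in this assay. Relative to compound 2 it carries 1-methyl-1H-imidazol-4-yl in place of 1-hydroxyethyl on an aromatic carbon.

Among the compounds with values here, no step between measured compounds informs this change, so any expectation rests on the two values seen. Both compound 1 and compound 2 sit at a similar level, and the new group is larger with one more ring. Compound 3 is expected to give 6500 ng.h/mL, within a range of 2500 ng.h/mL to 18000 ng.h/mL. The step expected from compound 2 is a 1.6-fold lower number from compound 2 to compound 3 (0.20 log units; within the scatter), a modest drop that may not exceed the scatter.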

Compound 3, area under the concentration-time curve: 698 ng.h/mL
Compound 3: the middle estimate sits 9.3-fold (0.97 log units) above what was measured; measured number below the stated range.
By their numbers in this assay, from the lowest: compound 3; then compounds 1 and 2 (each within the scatter of the next).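

In this assay, the position on an aromatic carbon between two ring nitrogen atoms proves sensitive to what it carries: 1-methyl-1H-imidazol-4-yl in place of 1-hydroxyethyl gives a 15-fold lower number from compound 2 to compound 3 (1.17 log units; beyond the scatter). Compound 1 and compound 2 differ in two places and lie within the scatter of each other, so they could not isolate this position; the present pair differs in that one place alone. The change adds a five-membered aromatic ring and removes the hydrogen-bond donor of the 1-hydroxyethyl group, but nothing available here accounts for the large step.

The compounds shown leave open whether the loss of exposure follows from the added ring, from the missing hydroxyl, or from the 1-methyl-1H-imidazol-4-yl group as a whole, and a small amine, a carboxylic acid or an imidazole ring without its methyl at this position could help to separate these possibilities. A single exposure figure for each compound also leaves open whether the step reflects how much compound is absorbed or how quickly it is cleared from the circulation.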